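From propyl to isopropyl on a ring nitrogen

The source may report more compounds than this note shows. Statements on the series, on what has been measured and on what is new or still open speak of the compounds shown alone.

Measured so far:
compound 1, `CCCNc1nnc(SCC(=O)N(Cc2cccc([N+](=O)[O-])c2)c2ccc(F)cc2)s1`, 8.5%
compound 2, `CC(C)CNc1nnc(SCC(=O)N(Cc2cccc([N+](=O)[O-])c2)c2ccc(F)cc2)s1`, 6.36%
Not yet measured: compound 3, `CC(C)Nc1nnc(SCC(=O)N(Cc2cccc([N+](=O)[O-])c2)c2ccc(F)cc2)s1`

For the measured compounds named here, in an assay on isolated protein for inhibition of Amine oxidase [flavin-containing] A (Homo sapiens), read by fluorescence and Amplex Red, with a stated time of 30 min, tested at 0.01 nM (a higher number here means a stronger effect of the compound at the concentration tested, a lower number a weaker effect), compound 1 gives 8.5%, the higher of the two numbers known, while compound 2 gives 6.36%. The step of a number 2.1 percentage points lower from compound 1 to compound 2 (within the scatter) stays within the scatter, so the two compounds cannot be told apart on these numbers.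

Compound 3 is reached from compound 1 by isopropyl in place of propyl on a nitrogen on an aromatic ring. Going by the values given here, the only step already known that touches this part of the molecule is the one from compound 1 to compound 2, which also adds branching to the chain hanging from the ring nitrogen, and that step was a number 2.1 percentage points lower from compound 1 to compound 2 (within the scatter), a change the assay cannot resolve. Among the compounds with values here, since both numbers known so far sit low in this assay and the one related change made no visible difference, no step beyond the scatter is expected here, and the estimate for the step is a number 1 percentage points lower from compound 1 to compound 3 (within the scatter).

For compound 3 the expected inhibition is 7.5%, with a range from 0% to 18%.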

Compound 3, a percentage reported as inhibition, at one concentration (the size of the read-out at that concentration, not a potency): 6.87%
The estimate for compound 3 lay 0.6 percentage points above the measured number, and the stated range covers the measured number.
By their numbers in this assay, from the lowest: compounds 2, 3 and 1 (each within the scatter of the next).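

In this assay, putting isopropyl in place of propyl on a nitrogen on an aromatic ring keeps the same atoms and only joins them differently, and this gives a number 1.6 percentage points lower from compound 1 to compound 3 (within the scatter). Putting isopropyl in place of isobutyl on that same nitrogen gives a number 0.5 percentage points higher from compound 2 to compound 3 (within the scatter). For the compounds shown here, the single earlier step compared only propyl with isobutyl, whereas these new steps show that neither moving the branch nor trimming the branched chain produces a difference this read-out can resolve, so propyl, isobutyl and isopropyl cannot be told apart here.

Whether a quite different group on this nitrogen, such as a longer chain like hexyl, a cyclohexyl ring or one carrying a carboxylic acid, would give a number clearly apart from these three remains open, since the compounds shown vary only among these alkyl groups. Nothing measured on these compounds speaks to why the three groups read alike.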